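This account rests on a few compounds, and the source may have more. Where it says the series, first, only, none or still open, it means among the compounds named here.

Measured so far in an assay on RBL-1 cells for inhibition of Polyunsaturated fatty acid 5-lipoxygenase (Rattus norvegicus); on this read-out lower numbers stand for stronger inhibition and higher numbers for weaker inhibition:
compound 1 `Cc1cccc(N2CC(C)NC(=O)N2)n1` — 3800 nM
compound 2 `CC1CN(c2cccc(F)n2)NC(=O)N1` — 6600 nM
compound 3 `O=C1NCCN(c2cccc(Cl)n2)N1` — 5600 nM

Compound 3 stands second highest of the three numbers in this assay; its distance to compound 2 and to compound 1 lies within the scatter, so no order among the three can be read. Compound 4 `CC1CN(c2cccc(Cl)n2)NC(=O)N1` differs from compound 3 by methyl in place of hydrogen on a saturated ring carbon. Among the compounds with values here, no measured step carries this change: the only single-point step, a 1.7-fold higher number from compound 1 to compound 2 (0.24 log units; within the scatter), concerns the aromatic substituent and lies within the scatter. Compounds 1 and 2 both carry the methyl on the saturated ring carbon and give numbers close to compound 3, which lacks it. A step of a 1.1-fold lower number from compound 3 to compound 4 (0.05 log units; within the scatter) is therefore expected, none beyond the scatter. Compound 4 is estimated at 5000 nM in this assay, in the range 2500 nM to 10000 nM.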

Compound 4, half-maximal inhibitory concentration: 3500 nM
Beside the measured number, compound 4's estimate is 1.4-fold (0.15 log units) above it; measured number inside the range.
By their numbers in this assay, from the lowest: compounds 4, 1, 3 and 2 (each within the scatter of the next).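

In this assay the methyl on the saturated ring carbon now has a direct reading: a 1.6-fold lower number from compound 3 to compound 4 (0.20 log units; within the scatter) stays within the scatter, so this change cannot be separated from no change. With that methyl held constant, the chloro, fluoro and methyl groups on the aromatic carbon also remain unresolved: a 1.9-fold lower number from compound 2 to compound 4 (0.28 log units; within the scatter) and a 1.1-fold lower number from compound 1 to compound 4 (0.04 log units; within the scatter) both lie within the scatter. Nothing available bears on the cause of these steps.

Open, as far as these compounds go, is whether an ethyl or longer chain on the saturated ring carbon, or an amine or carboxylic acid on the aromatic carbon, would give a step beyond the scatter.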